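What one fluoro might do to compound 1

The compounds below may be only part of what the source reports. "The series", "measured", "known", "first", "only" and "open" are said of these compounds alone.

Among the compounds with values here, in a functional assay on KM12 cells (Homo sapiens) for antiproliferative activity (a lower number here means a stronger inhibitor of growth, a higher number a weaker inhibitor of growth), compound 1 `COc1ccc(-c2nc3ccccc3s2)cc1OC` gives 74200 nM, the highest number of the three compounds measured so far. Compound 2 `COc1ccc(-c2nc3cc(F)ccc3s2)cc1` comes in lower at 24600 nM, and compound 3 `COc1ccc(-c2nc3cc(F)ccc3s2)cc1Br` lower again at 6700 nM. Both of these gaps to compound 1 lie beyond the usual scatter.

Compound 4 `COc1ccc(-c2nc3cc(F)ccc3s2)cc1OC` has not yet been measured. It differs from compound 1 by a single change: fluoro in place of hydrogen on an aromatic carbon.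

Within the data shown here, no measured step makes exactly this change, so the evidence is indirect. Compound 2 and compound 3 both carry the fluoro, and both sit below compound 1, which points toward a lower number. Among the measured compounds shown here, the one measured step, a 3.7-fold lower number from compound 2 to compound 3 (0.56 log units; beyond the scatter), is bromo in place of hydrogen on an aromatic carbon. It shows that one swap among fluoro-bearing compounds can move the number beyond the scatter. Steps in so small a set need not simply add up, so the direction is firmer than the size. A clear drop is expected, and the estimated step is a 74-fold lower number from compound 1 to compound 4 (1.87 log units; beyond the scatter). Compound 4 is estimated at 1000 nM, with an expected range of 10 nM to 20000 nM.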

Compound 4, concentration for 50% growth inhibition: 290 nM
The estimate for compound 4 lay 3.4-fold (0.54 log units) above the measured number; low and high end bracket the measured number.
By their numbers in this assay, from the lowest: compound 4; then compound 3; then compound 2; then compound 1.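

Fluoro in place of hydrogen at this aromatic carbon, meta to a fused ring and para to a fused ring, has a large effect in this assay when both methoxy groups are present, as the direct reading gives a 260-fold lower number from compound 1 to compound 4 (2.41 log units; beyond the scatter) for this single heavy atom. With the fluoro held in place, the group at the other site matters just as much: methoxy in place of hydrogen gives an 85-fold lower number from compound 2 to compound 4 (1.93 log units; beyond the scatter) and methoxy in place of bromo gives a 23-fold lower number from compound 3 to compound 4 (1.36 log units; beyond the scatter), whereas bromo in place of hydrogen at that same site gave only a 3.7-fold lower number from compound 2 to compound 3 (0.56 log units; beyond the scatter), so among these three compounds methoxy is the clear best choice there. No measurement shown here explains why these steps are so large.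

On these data alone, the fluoro has been read only in this one pair, so its effect on a core without the second methoxy remains unknown, as does the outcome of chloro or a nitrile in its place. Within the data shown here, it is also open whether methoxy is the only group that works at the other site, or whether an ethoxy, a longer chain or an amine there would give a similarly low number.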